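Hydroxypyrrolidine for cyclobutyl on the sulfonyl sulfur

A few compounds are considered here, and "the series" means these few. Any claim that something is new, unique, unknown or untested is made for them only; others in the source may bear on it.

Compound 1 `O=C([C@@H]1CCCN(S(=O)(=O)c2ccc(S(=O)(=O)C3CCC3)cc2)C1)N1CCC(F)(F)CC1`: 78 nM
Compound 2 `CCN(CC)S(=O)(=O)c1ccc(S(=O)(=O)N2CCC[C@@H](C(=O)N3CCS(=O)(=O)CC3)C2)cc1`: 4430 nM
Compound 3 `CCN(CC)S(=O)(=O)c1ccc(S(=O)(=O)N2CCC[C@@H](C(=O)N3CCC(O)CC3)C2)cc1`: 4710 nM

In a functional assay on BXPC-3 cells (Homo sapiens) for inhibition, read by MTT assay, with a stated time of 7 days (a higher number here means a weaker inhibitor, a lower number a stronger inhibitor), compound 1 gives the lowest number of the three, with compound 2 and compound 3 far behind. Going by the values given here, the only measured step, a 1.1-fold higher number from compound 2 to compound 3 (0.03 log units; within the scatter), concerns the carbonyl end, not the sulfonyl sulfur. Compound 4 `O=C([C@@H]1CCCN(S(=O)(=O)c2ccc(S(=O)(=O)N3CC[C@H](O)C3)cc2)C1)N1CCC(F)(F)CC1` keeps the carbonyl end of compound 1 and changes the sulfonyl end: 3-hydroxypyrrolidin-1-yl in place of cyclobutyl on a sulfonyl sulfur. Among the compounds with values here, compounds 2 and 3 also carry a nitrogen on that sulfur, but they differ from compound 1 at the carbonyl end as well, so no measured step isolates the change. The author therefore expects a modest loss beyond the scatter, a 3.8-fold higher number from compound 1 to compound 4 (0.59 log units; beyond the scatter), and estimates that compound 4 will give 300 nM, between 80 nM and 1500 nM.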

Compound 4, half-maximal inhibitory concentration: 580 nM
Compound 4: the middle estimate sits 1.9-fold (0.29 log units) below what was measured; the range from low to high includes it.
By their numbers in this assay, from the lowest: compound 1; then compound 4; then compounds 2 and 3 (each within the scatter of the next).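

With the carbonyl end held fixed, the change at the sulfonyl sulfur can now be read on its own in this assay: 3-hydroxypyrrolidin-1-yl in place of cyclobutyl gives a 7.4-fold higher number from compound 1 to compound 4 (0.87 log units; beyond the scatter). Going by these compounds alone, the number rises beyond the scatter, so this position is sensitive to this exchange, a point the earlier compounds could not isolate. Nothing available accounts for the step.

The compounds shown leave open whether the hydroxyl or the ring itself goes with this step, as a plain pyrrolidin-1-yl would tell. Going by these compounds, how a morpholin-4-yl or a small methyl group on that sulfur would read also stays open.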